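Adding a Methyl Where Two Compounds Show Only Limits

A few compounds are considered here, and "the series" means these few. Any claim that something is new, unique, unknown or untested is made for them only; others in the source may bear on it.

Compound 1 `N#Cc1cc2cc(-c3cccs3)n(O)c2cc1C#N` and compound 2 `COn1c(-c2ccccc2)c(C=O)c2cc(C#N)c(C#N)cc21` were both tested in an assay on isolated protein for inhibition of Amine oxidase [flavin-containing] B (Homo sapiens), read by fluorescence and spectrophotometry, with a stated time of 20 min; on this read-out higher numbers stand for weaker inhibition and lower numbers for stronger inhibition. For compound 1 the result is only a limit of the assay, > 100000 nM. For compound 2 the result is likewise a limit of the assay, > 100000 nM. Among the measured compounds shown here, compound 2 thus stands where the assay stops counting, and so does the one other value shown, as the limit of > 100000 nM in this assay, at which 2 of the 2 values shown sit, summarises. Compound 3 `COn1c(-c2ccc(C)cc2)c(C=O)c2cc(C#N)c(C#N)cc21` differs from compound 2 by a single change, (methyl in place of hydrogen on an aromatic carbon), methyl in place of hydrogen on an aromatic carbon. For the measured compounds named here, no step between measured compounds is available to show what such a change does in this assay. Starting from a limit, the expected step is a step that the limit leaves unreadable from compound 2 to compound 3, which is to say none beyond the scatter. Compound 3 is therefore expected to give about 150000 nM in this assay. That estimate for compound 3 spans a range from 50000 nM to 500000 nM, most likely reported again as a limit.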

Compound 3, half-maximal inhibitory concentration: 74800 nM
For compound 3 the middle estimate is 2.0-fold (0.30 log units) above the measured one, and the stated range covers the measured number.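

In this assay, methyl in place of hydrogen on an aromatic carbon, para to a large group, gives an at least 1.3-fold lower number from compound 2 to compound 3 (0.12 log units; that floor lies within the scatter). Compound 3 is the only compound shown with a measured number rather than a limit, so this position can carry a methyl without the value staying out of the assay's range. The real size of the step stays unknown, and the floor printed with it does not show that the change does more than the scatter, as most values here still sit at a limit: the limit of > 100000 nM in this assay, at which 2 of the 3 values shown sit.

The compounds shown leave open whether a longer chain such as ethyl, or a chlorine atom, at this same position would lower the number further. They also leave open how an amine or a carboxylic acid there would compare with the methyl of compound 3.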